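The compounds below may be only part of what the source reports. "The series", "measured", "known", "first", "only" and "open" are said of these compounds alone.

Measured compounds:
compound 1 `O=C(Nc1cccc(-n2cc(-c3ccncc3)c(-c3cc(O)cc(Cl)c3)n2)c1)Nc1ccc(Cl)c(Cl)c1`, in a functional assay on SW-620 cells (Homo sapiens) for inhibition, read by sulforhodamine B assay, with a stated time of 48 h, tested at 1 uM (on this read-out higher numbers stand for a weaker effect at the one concentration tested and lower numbers for a stronger effect), compound 1 gives 102%
compound 2 `COc1cc(Cl)cc(-c2nn(-c3cccc(NC(=O)Nc4ccc(Cl)c(Cl)c4)c3)cc2-c2ccncc2)c1`, in this assay compound 2 gives 93%

Compound 2 stands lowest of the two numbers, with compound 1 its nearest neighbour; the step of a number 9 percentage points lower from compound 1 to compound 2 (within the scatter) is within the scatter. Compound 3 `COc1cc(Cl)cc(-c2nn(-c3cccc(NC(=O)c4cccc(C(F)(F)F)c4)c3)cc2-c2ccncc2)c1` differs from compound 2 by 3-(trifluoromethyl)phenyl in place of (3,4-dichlorophenyl)amino on a carbonyl carbon. Going by the values given here, no measured step touches the carbonyl carbon; the only measured step concerns an oxygen elsewhere and gives no guidance here. Both measured numbers sit near the no-effect level, so no step beyond the scatter is expected. Compound 3 is estimated at 95% (range 72% to 108%), a step of a number 2 percentage points higher from compound 2 to compound 3 (within the scatter) expected.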

Compound 3, a percentage reported as activity, at one concentration (the size of the read-out at that concentration, not a potency): 107%
For compound 3 the middle estimate is 12 percentage points below the measured one; the measured number falls inside the stated range.
By their numbers in this assay, from the lowest: compounds 2, 1 and 3 (each within the scatter of the next, the first and the last beyond it).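

In this assay, going by these compounds alone, the change on the carbonyl carbon gives a number 14 percentage points higher from compound 2 to compound 3 (beyond the scatter) and is the first step beyond the scatter, towards a weaker effect at the single concentration tested. The swap removes the (3,4-dichlorophenyl)amino nitrogen and changes the ring substituents in one step, so the result cannot assign the shift to either. Nothing available bears on the reason for this step.

Still open, on these data alone, is how 3-(trifluoromethyl)phenylamino on the same carbonyl carbon would read, which would separate the nitrogen from the ring substituents. As far as these compounds go, a non-aromatic amine such as piperidine at this position is also open.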